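Trifluoromethyl on the pyridine amide of a fluorobenzonitrile core

A few compounds are considered here, and "the series" means these few. Any claim that something is new, unique, unknown or untested is made for them only; others in the source may bear on it.

Measured compounds in an in vitro functional assay on HEK293-A cells for antagonist activity at metabotropic glutamate receptor 5 (Rattus norvegicus), read by calcium flux; on this read-out lower numbers stand for stronger inhibition and higher numbers for weaker inhibition:
Compound 1 `N#Cc1cc(F)cc(C(=O)Nc2ccccn2)c1` gives 3010 nM.
Compound 2 `Cn1ccc(NC(=O)c2cc(F)cc(C#N)c2)n1` gives only a limit, > 10000 nM.
Compound 3 `N#Cc1cc(F)cc(C(=O)Nc2ccon2)c1` gives only a limit, > 30000 nM.

Going by the values given here, compound 1 is the only compound of the three with a numerical value in this assay; the other two values are limits. Replacing its pyridin-2-yl with 1-methyl-1H-pyrazol-3-yl gives an at least 3.3-fold higher number from compound 1 to compound 2 (0.52 log units; beyond the scatter), and replacing it with 1,2-oxazol-3-yl gives an at least 9.9-fold higher number from compound 1 to compound 3 (0.99 log units; beyond the scatter). The step from compound 2 to compound 3 is a step that the two limits leave unreadable from compound 2 to compound 3.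

Compound 4 `N#Cc1cc(F)cc(C(=O)Nc2cccc(C(F)(F)F)n2)c1` keeps the pyridin-2-yl of compound 1 and differs from it only by trifluoromethyl in place of hydrogen on an aromatic carbon. Among the compounds with values here, none of the measured steps alters a substituent on a retained ring; all three exchange the ring itself, so they bear on compound 4 only in showing that this assay is sensitive to changes at the amide nitrogen. Against that background, compound 4 is expected to sit close to compound 1 or somewhat lower, a step of a 2.0-fold lower number from compound 1 to compound 4 (0.30 log units; within the scatter), with the uncertainty wide in both directions. Compound 4 is therefore estimated at 1500 nM, within a range from 300 nM to 8000 nM.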

Compound 4, half-maximal inhibitory concentration: > 10000 nM
Compound 4 ended at the assay's limit; the forecaster's own chance of this, stated with the estimate: 15%; at least 6.6-fold (0.82 log units) between middle value and limit.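

In this assay, going by these compounds alone, the earlier compounds all exchanged the ring on the amide nitrogen, whereas this change keeps the pyridin-2-yl of compound 1 and still weakens inhibition: trifluoromethyl in place of hydrogen on an aromatic carbon, next to the ring nitrogen, gives an at least 3.3-fold higher number from compound 1 to compound 4 (0.52 log units; beyond the scatter). Within the data shown here, a single substituent at this place on the retained ring is therefore enough to move the read-out beyond the usual scatter, so exchanging the ring is not the only kind of change at this end of the molecule that matters. How far the weakening goes cannot be read, because the result for compound 4 is a limit and not a number: the limit of > 10000 nM in this assay, at which 2 of the 4 values shown sit.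

Whether the loss is particular to trifluoromethyl stays open, since the compounds shown do not tell how a methyl group, a chlorine atom or an amine would behave at this same place. Also open is how trifluoromethyl would behave on another carbon of the same six-membered aromatic ring, which the compounds shown do not address.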